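Replacing the open hydroxyethyl amide of compound 1

The compounds below may be only part of what the source reports. "The series", "measured", "known", "first", "only" and "open" are said of these compounds alone.

Values measured so far in a functional assay on U-87MG ATCC cells for inhibition, with U-87 MG (Homo sapiens) as the target, read by sulforhodamine B assay, with a stated time of 72 h (a higher number here means a weaker inhibitor of growth, a lower number a stronger inhibitor of growth), are these
compound 1 `COc1ncc(-c2ccc3nccc(/C(C)=C/C(=O)N(C)CCO)c3c2)cc1NS(=O)(=O)c1ccc(F)cc1F` gives 380 nM
compound 2 `COc1ncc(-c2ccc3nccc(/C(C)=C/C(=O)N4CCN(C)CC4)c3c2)cc1NS(=O)(=O)c1ccc(F)cc1F` gives 140 nM
compound 3 `COc1ncc(-c2ccc3nccc(/C(C)=C\C(=O)N4CCOCC4)c3c2)cc1NS(=O)(=O)c1ccc(F)cc1F` gives > 10000 nM as a limit of the assay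

Compound 1 at 380 nM holds the higher of the two actual numbers, and compound 2 lies nearest at 140 nM in the same assay. Compound 3 stands at > 10000 nM which is a limit and not a number.

Compound 4 `COc1ncc(-c2ccc3nccc(/C(C)=C/C(=O)N4CCC(O)CC4)c3c2)cc1NS(=O)(=O)c1ccc(F)cc1F` carries 4-hydroxypiperidin-1-yl in place of (2-hydroxyethyl)(methyl)amino on a carbonyl carbon so the entering group brings one six-membered non-aromatic ring where the leaving group has no ring.

Among the compounds with values here, the closest precedent is a 2.7-fold lower number from compound 1 to compound 2 (0.43 log units; beyond the scatter) which is modest and replaces the same group on that carbonyl carbon. The large steps of an at least 26-fold higher number from compound 1 to compound 3 (1.42 log units; beyond the scatter) and an at least 71-fold higher number from compound 2 to compound 3 (1.85 log units; beyond the scatter) each exchange the whole 1-methylethenyl substituent and end at a limit, so they are a poor guide here. Going by compound 2 and its modest 2.7-fold lower number from compound 1 to compound 2 (0.43 log units; beyond the scatter) in this assay no step larger than that is expected, and the direction remains open.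

For compound 4 the estimated step is a 1.3-fold lower number from compound 1 to compound 4 (0.10 log units; within the scatter) with no change beyond the scatter expected. Compound 4 is estimated at 300 nM with 100 nM to 900 nM as the expected range.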

Compound 4, concentration for 50% growth inhibition: 600 nM
The estimate for compound 4 lay 2.0-fold (0.30 log units) below the measured number; low and high end bracket the measured number.
By their numbers in this assay, from the lowest: compound 2; then compounds 1 and 4 (each within the scatter of the next). At a limit, above all of these: compound 3.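

In this assay, closing the open (2-hydroxyethyl)(methyl)amino group into 4-hydroxypiperidin-1-yl on the carbonyl carbon gives a 1.6-fold higher number from compound 1 to compound 4 (0.20 log units; within the scatter), so at this position the added six-membered ring brings no change beyond the scatter. The same position now also has a comparison between two ring amides, a 4.3-fold higher number from compound 2 to compound 4 (0.63 log units; beyond the scatter), which shows that the presence of a ring does not alone set the number and that the choice of ring matters. The step of an at least 16-fold lower number from compound 3 to compound 4 (1.22 log units; beyond the scatter) exchanges the whole 1-methylethenyl substituent and so does not isolate the amide group, and it starts from compound 3, whose reading is a limit of the assay: the limit of > 10000 nM in this assay, at which 1 of the 4 values shown sits.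

The compounds shown do not tell whether the lower number of compound 2 follows from the ring nitrogen or from its methyl group, and an unsubstituted piperazine or a 4-(dimethylamino)piperidine would separate the two. Also open, on these data alone, is how a morpholin-4-yl amide reads with the double-bond arrangement of compound 1, which would separate the amide change from the arrangement in compound 3.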